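The source may report more compounds than this note shows. Statements on the series, on what has been measured and on what is new or still open speak of the compounds shown alone.

Three close relatives of a shared core have been tested for their effect on the growth of a human brain tumour cell line. Compound 3, `ClCc1ccc(Cn2cnc3c(Cl)nc(Cl)nc32)cc1`, and compound 2, `ClCc1cccc(Cn2cnc3c(Cl)nc(Cl)nc32)c1`, are built from the same atoms joined differently; the difference between the two cores is not broken down here. In a functional assay on SNB-19 cells (Homo sapiens) for cytotoxicity, read by sulforhodamine B assay, with a stated time of 48 h (a lower number here means a stronger inhibitor of growth, a higher number a weaker inhibitor of growth), compound 3 gives 2510 nM, and in the same setting compound 2 gives 1950 nM, two values that lie within the usual scatter of each other. Compound 1, `Nc1nc(Cl)c2ncn(Cc3ccc(CCl)cc3)c2n1`, arises from compound 3 by a single change, (amino in place of chloro on an aromatic carbon), and in this assay compound 1 gives 6760 nM. That change made a step of a 2.7-fold higher number from compound 3 to compound 1 (0.43 log units; beyond the scatter), so the amino compound holds back growth somewhat less than its chloro parent.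

The same change, applied to compound 2 instead, gives compound 4, `Nc1nc(Cl)c2ncn(Cc3cccc(CCl)c3)c2n1`, which has not yet been measured. The difference is again (amino in place of chloro on an aromatic carbon), at the very same kind of place in the molecule as before. Within the data shown here, since the only measured example of this change, from compound 3 to compound 1, gave a 2.7-fold higher number from compound 3 to compound 1 (0.43 log units; beyond the scatter), a step of comparable size is expected here, namely a 2.7-fold higher number from compound 2 to compound 4 (0.43 log units; beyond the scatter). On that basis, compound 4 in this assay is estimated at 5300 nM, with a likely range from 2600 nM to 10500 nM, because the starting point of compound 2 is 1950 nM.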

Compound 4, concentration for 50% growth inhibition: 3160 nM
Compound 4: middle estimate off by 1.7-fold (0.22 log units), on the high side; the range from low to high includes it.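

In this assay, amino in place of chloro on an aromatic carbon gives a 1.6-fold higher number from compound 2 to compound 4 (0.21 log units; within the scatter), so on this core the effect of the change cannot be told apart from the ordinary variation between repeated measurements. Set beside the earlier example, the two steps agree as closely as such measurements allow: the same change on two cores in this assay, a 2.7-fold higher number (0.43 log units; beyond the scatter) from compound 3 to compound 1 and a 1.6-fold higher number (0.21 log units; within the scatter) from compound 2 to compound 4, 1.7-fold (0.22 log units) apart, within the scatter of two such steps

Among these compounds, this shows that the change can be carried from one of these cores to the other with no sign of a different effect, but it rests on only two pairs of compounds, and only one of the two steps stands clear of the scatter on its own. It does not show that the change makes a real difference on both cores, nor does it show how the step would behave on any core beyond these two.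

The compounds shown leave open how a methylamino or a methoxy group, placed on the same carbon between two ring nitrogen atoms, would compare with amino and chloro. They also leave open whether the step would keep its size if the chloromethyl group gave way to a hydroxymethyl group or a longer chain.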